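Ring-nitrogen position change at the arylidene end of the core

This account rests on a few compounds, and the source may have more. Where it says the series, first, only, none or still open, it means among the compounds named here.

Working notes on a small series sharing one core, that of compound 1 `COc1ccc(/C=C2\SC(=O)N(Cc3ccc(C(=O)O)cc3)C2=O)cc1`. In a functional assay on A549 cells (Homo sapiens) for cytotoxicity, read by MTT assay, with a stated time of 24 h (a lower number here means a stronger inhibitor, a higher number a weaker inhibitor), compound 1 gives 44000 nM, compound 3 `COc1cc(/C=C2\SC(=O)N(Cc3ccc(C(=O)O)cc3)C2=O)cc(OC)c1OC` gives 36000 nM, and compound 2 `O=C(O)c1ccc(CN2C(=O)S/C(=C\c3cccnc3)C2=O)cc1` gives 75000 nM. Compound 2 thus carries the highest of the three numbers; compound 1 sits within the scatter of it, compound 3 lies a step beyond the scatter below it.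

The next compound, compound 4 `O=C(O)c1ccc(CN2C(=O)S/C(=C\c3ccccn3)C2=O)cc1`, keeps the same atoms joined differently: pyridin-2-yl in place of pyridin-3-yl on a double-bonded chain carbon bound to a double-bonded ring carbon. Among the measured compounds shown here, the single measured step at this place is a 1.7-fold higher number from compound 1 to compound 2 (0.23 log units; within the scatter), which swaps one aromatic ring for another without leaving the scatter. For the measured compounds named here, no measured pair tests a change of the nitrogen position within the same ring, so the only bearing evidence is that replacements at this position have so far moved the number little. In this assay compound 4 is therefore expected to stay close to compound 2, with an expected step of a 1.1-fold lower number from compound 2 to compound 4 (0.03 log units; within the scatter), no direction favoured. The estimate for compound 4 is 70000 nM, with a range from 30000 nM to 160000 nM.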

Compound 4, half-maximal inhibitory concentration: 80000 nM
Compound 4: middle estimate off by 1.1-fold (0.06 log units), on the low side; measured number inside the range.
By their numbers in this assay, from the lowest: compounds 3, 1, 2 and 4 (each within the scatter of the next, the first and the last beyond it).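

Compound 4 gives the first direct test of moving the ring nitrogen within the same aromatic ring at this place, and the move from pyridin-3-yl to pyridin-2-yl does not register in this assay (a 1.1-fold higher number from compound 2 to compound 4 (0.03 log units; within the scatter)). Replacing 4-methoxyphenyl with pyridin-2-yl also stays within the scatter (a 1.8-fold higher number from compound 1 to compound 4 (0.26 log units; within the scatter)), as the replacement with pyridin-3-yl did, so neither ring-nitrogen placement shown separates from compound 1. No measurement here offers an explanation for this result.

On these data alone, a pyridin-4-yl group at the same place would complete the set of ring-nitrogen positions, and its number remains open. Also open, as far as these compounds go, is whether an amine or a carboxylic acid on the pyridine ring would move the number beyond the scatter.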